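This account rests on a few compounds, and the source may have more. Where it says the series, first, only, none or still open, it means among the compounds named here.

Compound 1 (`NS(=O)(=O)CC(=O)NCCSc1nonc1/C(=N/O)Nc1cccc(Cl)c1`): > 3 h
Compound 2 (`CS(=N)(=O)CC(=O)NCCSc1nonc1/C(=N/O)Nc1ccc(F)c(Br)c1`): 2.65 h

In an ADME assay on microsomes from liver (Homo sapiens) for metabolic stability (a higher number here means that the compound lasts longer, a lower number that the compound disappears faster), compound 1 gives > 3 h as its reading, and this is a limit of the assay, not a number. Compound 3 (`NS(=O)(=O)CC(=O)NCCSc1nonc1/C(=N/O)Nc1cccc(Br)c1`) differs from compound 1 in one place (bromo in place of chloro on an aromatic carbon): bromo in place of chloro on an aromatic carbon. Among the measured compounds shown here, no measured pair of compounds shows this swap. The expectation therefore rests on the limit of compound 1 at > 3 h and on nothing more. The estimated step that the limit leaves unreadable from compound 1 to compound 3 is expected to stay within the scatter of this assay for this swap. For compound 3 the estimated half-life is 3.3 h with 2 h to 6 h as the expected range.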

Compound 3, half-life: > 3 h
Compound 3: only a limit was reported; the forecaster's own chance of this, stated with the estimate: 55%; the middle value is on the limit's open side.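

In this assay no step can be read from compound 1 to compound 3, as both readings are limits of the assay: the limit of > 3 h in this assay, at which 2 of the 3 values shown sit. Going by these compounds, what stays open is how long compound 1 and compound 3 actually last, and so whether bromo in place of chloro on an aromatic carbon changes the half-life at all.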